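A few compounds are considered here, and "the series" means these few. Any claim that something is new, unique, unknown or untested is made for them only; others in the source may bear on it.

The study concerns three measured compounds and one that awaits measurement, all examined in a functional assay on the whole organism (strain albino) for inhibition, with Rattus norvegicus as the target, read by paw edema, with stated times of 30 min and 4 h, at a dose of 0.28 mmol/kg by the oral route; on this read-out higher numbers stand for more inhibition at the one dose given (going by the name of the read-out) and lower numbers for less inhibition. Compound 1 `COc1cc(-c2nnc(SCC(=O)Nc3ccc(/C(C)=N/O)cc3)n2-c2ccccc2)cc(OC)c1OC` gives 75% in this assay. Compound 2 `COc1ccc(-c2nnc(SCC(=O)Nc3ccc(/C(C)=N/O)cc3)n2-c2ccccc2)cc1OC` gives 79% in this assay; the structural change between the two is hydrogen in place of methoxy on an aromatic carbon, and the step reads a number 4 percentage points higher from compound 1 to compound 2 (within the scatter). Compound 3 `C=CCn1c(SCC(=O)Nc2ccc(/C(C)=N/O)cc2)nnc1-c1ccc(OC)c(OC)c1` gives 79% in this assay, and the step reads no change at the digits printed from compound 2 to compound 3 (within the scatter). Compound 3 and compound 2 therefore lie within the scatter of each other, and the same holds for compound 3 against compound 1. The difference between the core of compound 3 and the core of compound 1 is not broken down here.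

Compound 4 `C=CCn1c(SCC(=O)Nc2ccc(/C(C)=N/O)cc2)nnc1-c1ccc(OC)cc1` has not yet been measured. It differs from compound 3 by hydrogen in place of methoxy on an aromatic carbon. Within the data shown here, this is the same kind of change as the one from compound 1 to compound 2, though not the same: in the earlier case the place was also meta to a methoxy group, and no such group stands around the place in compound 4. The expected step for compound 4 is a number 1 percentage points higher from compound 3 to compound 4 (within the scatter). That expectation rests on the step of a number 4 percentage points higher from compound 1 to compound 2 (within the scatter), which lay within the scatter, so no large movement is anticipated for the like change. Compound 4 is expected to give about 80%, between 70% and 88%, in this assay.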

Compound 4, a percentage reported as inhibition, in the whole organism at one dose (the size of the read-out at that dose, not a potency): 75%
Compound 4: the middle estimate sits 5 percentage points above what was measured; the measured number falls inside the stated range.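

In this assay, the exchange of 3,4-dimethoxyphenyl for 4-methoxyphenyl gives a number 4 percentage points lower from compound 3 to compound 4 (within the scatter), so taking away this methoxy group leaves the reading of the allyl compound within the usual spread of such measurements. Set beside the same kind of change on the core of compound 1, the new step does not differ from the earlier one: the same change on two cores in this assay, a number 4 percentage points higher (within the scatter) from compound 1 to compound 2 and a number 4 percentage points lower (within the scatter) from compound 3 to compound 4, 8 percentage points apart, within the scatter of two such steps. Across these two cores, hydrogen in place of methoxy therefore stayed within the scatter each time, but the opposite signs of the two steps cannot be read as a true reversal, and two pairs measured at a single dose do not show that the change would behave in the same way on any further core.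

All the compounds shown keep at least one methoxy group on the aromatic ring, so it remains open what an unsubstituted phenyl, a chlorine atom, a hydroxyl group or an amine would do in that part of the molecule. Among these compounds, also open are a longer chain in place of the allyl group and a carboxylic acid in place of the oxime, since these parts offer no comparison here beyond the single step from phenyl to allyl.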